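The source may report more compounds than this note shows. Statements on the series, on what has been measured and on what is new or still open speak of the compounds shown alone.

Measured so far:
Compound 1, `Fc1ccccc1NCn1nc(-c2ccc3c(c2)OCCO3)oc1=S`: 6390 nM
Compound 2, `Fc1cccc(NCn2nc(-c3ccc4c(c3)OCCO4)oc2=S)c1`: 6620 nM
Compound 3, `FC(F)(F)c1ccccc1NCn1nc(-c2ccc3c(c2)OCCO3)oc1=S`: 9220 nM

All three were tested in a functional assay, with a stated time of 6 min; a lower number here means a stronger inhibitor, a higher number a weaker inhibitor. Compound 1 and compound 2 share the same atoms joined differently; the difference between their cores is 3-fluorophenyl in place of 2-fluorophenyl on an amine nitrogen. In this assay the step of a 1.0-fold higher number from compound 1 to compound 2 (0.02 log units; within the scatter), so the two cannot be told apart by these numbers. Compound 3 is reached from compound 1 by a single change, (trifluoromethyl in place of fluoro on an aromatic carbon), and the step of a 1.4-fold higher number from compound 1 to compound 3 (0.16 log units; within the scatter).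

Compound 4, `FC(F)(F)c1cccc(NCn2nc(-c3ccc4c(c3)OCCO4)oc2=S)c1`, has not yet been measured in this assay. It is reached from compound 2 by trifluoromethyl in place of fluoro on an aromatic carbon. Among the compounds with values here, this is the same kind of change as the one from compound 1 to compound 3, but not the same change: in compound 1 the fluoro that leaves sits ortho to a large group, whereas in compound 2 it sits meta to a large group. Within the data shown here, since the one measured example of this kind of change, the step from compound 1 to compound 3 of a 1.4-fold higher number from compound 1 to compound 3 (0.16 log units; within the scatter), stayed within the scatter, the step for compound 4 is expected to be of a similar size, a 1.4-fold higher number from compound 2 to compound 4 (0.13 log units; within the scatter), resting on that single example alone. On that basis compound 4 is expected to give about 9000 nM in this assay, estimated to fall between 4500 nM and 18000 nM.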

Compound 4, half-maximal inhibitory concentration: 7620 nM
For compound 4 the middle estimate is 1.2-fold (0.07 log units) above the measured one; the range from low to high includes it.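

In this assay, putting trifluoromethyl in place of fluoro on the core of compound 2 gives a small step, a 1.2-fold higher number from compound 2 to compound 4 (0.06 log units; within the scatter), so these two compounds cannot be told apart by their numbers. The same swap on a second core gave a similarly small step, so in these two cases the result carries over from one core to the other: the same change on two cores in this assay, a 1.4-fold higher number (0.16 log units; within the scatter) from compound 1 to compound 3 and a 1.2-fold higher number (0.06 log units; within the scatter) from compound 2 to compound 4, 1.3-fold (0.10 log units) apart, within the scatter of two such steps. Within the data shown here, this shows only that the swap made no clear difference in either pair; with just two examples, neither rising above the scatter, it does not show that a swap with a clear effect on one core would keep that effect on another, nor that this swap would stay small on other cores.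

The compounds shown leave open how a nitrile, a methoxy group or a carboxylic acid on the same aromatic ring would read in this assay, since only fluoro and trifluoromethyl appear there. They also leave open what a longer chain in place of the link to the amine nitrogen would do, and whether any change to the ring system shared by all four compounds, such as a carbonyl in place of the ring sulfur, would move the numbers more than these swaps did.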